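This account rests on a few compounds, and the source may have more. Where it says the series, first, only, none or still open, it means among the compounds named here.

Compound 1 `O=C(Nc1ccccc1)c1cnc(NCc2c(F)ccc3c2CCO3)n2cnnc12`: 4.1
Compound 2 `COCCC(=O)Nc1cnc(NCc2c(F)ccc3c2CCO3)n2cnnc12`: 1.4
Compound 3 `CN(c1ccccc1)c1cnc(NCc2c(F)ccc3c2CCO3)n2cnnc12`: 3.6

In a physicochemical assay for lipophilicity, using the shake flask method, in phosphate buffer, measured as octanol-water partition, with a stated time of 30 min, at pH 7.4 (a lower number here means a more polar compound, a higher number a more lipophilic compound), compound 3 stands second of the three, with 3.6, below compound 1 and above compound 2. Compound 4 `CN(C(=O)c1ccccc1)c1cnc(NCc2c(F)ccc3c2CCO3)n2cnnc12` differs from compound 3 by benzoyl in place of phenyl on a nitrogen on an aromatic ring. For the measured compounds named here, two measured steps bear on this change, although both fall on an aromatic carbon: the modest a number 0.50 log units lower from compound 1 to compound 3 (beyond the scatter) and the large a number 2.20 log units higher from compound 2 to compound 3 (beyond the scatter). These steps point opposite ways, so they bracket compound 3 rather than fix a direction. The larger step carries more weight, and a moderate fall is expected. The expected step is a number 0.80 log units lower from compound 3 to compound 4 (beyond the scatter). Compound 4 is estimated at 2.8, with an expected range from 2.1 to 3.5.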

Compound 4, distribution coefficient: 2.4
Compound 4: middle estimate off by 0.40 log units, on the high side; the range from low to high includes it.
By their numbers in this assay, from the lowest: compound 2; then compound 4; then compound 3; then compound 1.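

In this assay, benzoyl in place of phenyl on this nitrogen gives a number 1.20 log units lower from compound 3 to compound 4 (beyond the scatter) and so shows that the number responds strongly to a change on the nitrogen itself, not only to a swap of the whole group on the aromatic carbon. The new number falls inside the earlier span, with a number 1.00 log units higher from compound 2 to compound 4 (beyond the scatter) and with a number 1.70 log units lower from compound 1 to compound 4 (beyond the scatter) as the two bounds. Nothing available accounts for the size of this step. Going by these compounds, whether an amine or a carboxylic acid in place of benzoyl, or a longer chain in place of the methyl on this nitrogen, would shift the number stays open.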